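This account rests on a few compounds, and the source may have more. Where it says the series, first, only, none or still open, it means among the compounds named here.

Measured compounds, each in an ADME assay on HFF cells (Homo sapiens) for cytotoxicity, with a stated time of 8 days; on this read-out lower numbers stand for higher toxicity in this test and higher numbers for lower toxicity in this test:
- Compound 1, `Nc1nc(NC2CCCCC2)c2ncn(/C=C3/CC3(CO)CO)c2n1`, gives > 300000 nM; this is a limit of the assay, not a number.
- Compound 2, `CC(C)CNc1nc(N)nc2c1ncn2/C=C1/CC1(CO)CO`, gives > 300000 nM; this too is a limit, not a number.
- Compound 3, `CCCOc1nc(N)nc2c1ncn2/C=C1/CC1(CO)CO`, gives > 300000 nM; again a limit, not a number.

Among the compounds with values here, compound 3 thus stands exactly where the other two stand: every reading shown sits at the limit of > 300000 nM in this assay, at which 3 of the 3 values shown sit, so no compound can be called more or less toxic than another. The three steps between them, a step that the two limits leave unreadable from compound 1 to compound 2, a step that the two limits leave unreadable from compound 1 to compound 3 and a step that the two limits leave unreadable from compound 2 to compound 3, cannot be sized because both ends of each sit at the limit of > 300000 nM in this assay, at which 3 of the 3 values shown sit.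

Compound 4, `CCCSc1nc(N)nc2c1ncn2/C=C1/CC1(CO)CO`, differs from compound 3 by propylsulfanyl in place of propoxy on an aromatic carbon. No measured step touches the group that enters, so nothing shown can size the step directly. What the data do show is that three different groups at this position all leave this assay at its limit. On that basis the step is expected to be a number no higher from compound 3 to compound 4 (the limit leaves the size open), none beyond the scatter. Compound 4 is therefore expected to give about 300000 nM, within a range from 100000 nM to 900000 nM, most likely again reported only as a limit.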

Compound 4, half-maximal cytotoxic concentration: > 300000 nM
Compound 4 was reported as a limit; the forecaster's own chance of this, stated with the estimate: 80%; the middle value lies on the limit itself.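

In this assay compound 4 gives > 300000 nM, which is a limit and not a number. No step linking compound 4 to compound 1, compound 2 or compound 3 can be read, because all four readings sit at the same limit: the limit of > 300000 nM in this assay, at which 4 of the 4 values shown sit.

The compounds shown leave open how toxic each one is in this assay, and whether any group at this position would give a measurable number.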